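The source may report more compounds than this note shows. Statements on the series, on what has been measured and on what is new or still open speak of the compounds shown alone.

Three measured members of the series share one core and differ only at the oxygen next to a carbonyl group. Compound 1 `COC(=O)C1=C(C)N(C)C(=O)NC1c1ccco1` gives 9% in an assay on membranes from HeLa cells for displacement of a labelled ligand from adenosine receptor A3 (Homo sapiens), read by scintillation counting, with a stated time of 180 min, tested at 1 uM; on this read-out lower numbers stand for less inhibition and higher numbers for more inhibition at the one concentration tested (going by the name of the read-out). Compound 2 `CCCOC(=O)C1=C(C)N(C)C(=O)NC1c1ccco1` gives 8% in this assay. Compound 3 `CC1=C(C(=O)OC(C)(C)C)C(c2ccco2)NC(=O)N1C` gives 54% in this assay, the highest of the three numbers, beyond the scatter against both others.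

The steps show a number 1 percentage points lower from compound 1 to compound 2 (within the scatter), whereas a number 45 percentage points higher from compound 1 to compound 3 (beyond the scatter) and a number 46 percentage points higher from compound 2 to compound 3 (beyond the scatter), so only the tert-butyl on this oxygen stands apart among these three.

Compound 4 `CC1=C(C(=O)OCc2ccccc2)C(c2ccco2)NC(=O)N1C` is the next member, and the change from compound 3 is benzyl in place of tert-butyl on an oxygen next to a carbonyl group, tert-butoxy to benzyloxy. Among the compounds with values here, no measured step involves a benzyl group here; the two large steps into compound 3 show that the group on this oxygen matters, but they do not say whether benzyl behaves like tert-butyl or like methyl and propyl. The estimate is therefore wide and placed between the two groups of numbers. For compound 4 the expected step is a number 24 percentage points lower from compound 3 to compound 4 (beyond the scatter). Compound 4 is expected to give 30% in this assay, with a range from 5% to 65%.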

Compound 4, a percentage reported as inhibition, at one concentration (the size of the read-out at that concentration, not a potency): 11%
The estimate for compound 4 lay 19 percentage points above the measured number; measured number inside the range.
By their numbers in this assay, from the lowest: compounds 2, 1 and 4 (each within the scatter of the next); then compound 3.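

In this assay the change to benzyl gives a number 43 percentage points lower from compound 3 to compound 4 (beyond the scatter) and so does not hold the level seen with tert-butyl. Benzyl instead falls in with methyl and propyl on this oxygen, with a number 2 percentage points higher from compound 1 to compound 4 (within the scatter) and a number 3 percentage points higher from compound 2 to compound 4 (within the scatter), which leaves tert-butyl as the only one of the four groups that stands apart. Nothing at hand gives a reason for this difference.

On these data alone, whether isopropyl or cyclohexyl on this oxygen would read with tert-butyl, or with methyl, propyl and benzyl, stays open, so the higher number cannot yet be tied to anything broader than tert-butyl itself. Also open, as far as these compounds go, is what an amine or a hydroxyl group on the propyl chain would do.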